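Swapping the Triazole Aryl Group for Trifluoromethylphenyl

The source may report more compounds than this note shows. Statements on the series, on what has been measured and on what is new or still open speak of the compounds shown alone.

Compound 1 `C=C1C[C@]23C[C@@]1(O)CC[C@H]2c1cc(Br)c(O)c(C)c1[C@@H]3Cn1cc(-c2ccccc2)nn1` and compound 2 `C=C1C[C@]23C[C@@]1(O)CC[C@H]2c1cc(Br)c(O)c(C)c1[C@@H]3Cn1cc(-c2ccccn2)nn1` share one core and differ only in the aromatic ring attached to the five-membered ring with three nitrogens. In a functional assay on SMMC-7721 cells (Homo sapiens) for cytotoxicity, read by MTT assay, with a stated time of 4 days (on this read-out higher numbers stand for weaker inhibition and lower numbers for stronger inhibition), compound 1 reaches only the limit of the method, > 20000 nM. In this assay compound 2 likewise gives only a limit, > 20000 nM. The step that the two limits leave unreadable from compound 1 to compound 2 therefore cannot be read, since both values sit at the limit of > 20000 nM in this assay, at which 2 of the 2 values shown sit. Compound 2 thus stands at the limit itself, with no number behind it.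

Compound 3 `C=C1C[C@]23C[C@@]1(O)CC[C@H]2c1cc(Br)c(O)c(C)c1[C@@H]3Cn1cc(-c2ccc(C(F)(F)F)cc2)nn1` changes the same spot: 4-(trifluoromethyl)phenyl in place of pyridin-2-yl on an aromatic carbon. For the measured compounds named here, the only measured step touching this position is a step that the two limits leave unreadable from compound 1 to compound 2, which has no readable size, and no trifluoromethyl group appears anywhere among the measured compounds. The expected step that the limit leaves unreadable from compound 2 to compound 3 is therefore one that cannot be told from the scatter, with a limit again the likeliest outcome. Compound 3 is estimated in this assay at 25000 nM, between 8000 nM and 80000 nM.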

Compound 3, half-maximal inhibitory concentration: 12800 nM
Compound 3: the middle estimate sits 2.0-fold (0.29 log units) above what was measured; measured number inside the range.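

For the compounds shown here, compound 3 is the only one of the three compounds with a real number rather than a limit, so a group at this spot on the triazole can bring the read-out within the range of this assay. Replacing pyridin-2-yl with 4-(trifluoromethyl)phenyl gives an at least 1.5-fold lower number from compound 2 to compound 3 (0.19 log units; that floor lies within the scatter), and adding trifluoromethyl to the phenyl ring gives an at least 1.5-fold lower number from compound 1 to compound 3 (0.19 log units; that floor lies within the scatter). Both steps are only floors, and their true sizes stay unknown because each starts from a compound at the limit: the limit of > 20000 nM in this assay, at which 2 of the 3 values shown sit.

From the compounds shown here alone, it remains open whether an amine or a carboxylic acid in place of trifluoromethyl on the phenyl ring would give a lower or a higher number. Going by these compounds, it is also open whether a longer alkyl chain could replace the aromatic ring on the triazole and still give a readable value.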